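Removing One Hydroxy from the Catechol Aryl Hydrazone

This account rests on a few compounds, and the source may have more. Where it says the series, first, only, none or still open, it means among the compounds named here.

Compound 3 `CN(C)CCn1cnnc1-c1cc(Oc2ccc(NC(=O)N/N=C/c3ccc(O)c(O)c3)cc2F)ccn1` gives 3240 nM in a functional assay on MKN-45 cells (Homo sapiens) for cytotoxicity, read by MTT assay, with a stated time of 72 h (a higher number here means a weaker inhibitor, a lower number a stronger inhibitor), the highest of the three numbers recorded there, though its distance from compound 1 lies within the scatter. Compound 1 `COc1ccc(/C=N/NC(=O)Nc2ccc(Oc3ccnc(-c4nncn4CCN(C)C)c3)c(F)c2)c(OC)c1` gives 1680 nM and compound 2 `CN(C)CCn1cnnc1-c1cc(Oc2ccc(NC(=O)N/N=C/c3ccc(F)cc3)cc2F)ccn1` gives 1030 nM. The step of a 1.9-fold higher number from compound 1 to compound 3 (0.29 log units; within the scatter) stays within the scatter, whereas a 3.1-fold higher number from compound 2 to compound 3 (0.50 log units; beyond the scatter) is modest but real. Compound 4 `CN(C)CCn1cnnc1-c1cc(Oc2ccc(NC(=O)N/N=C/c3ccc(O)cc3)cc2F)ccn1` differs from compound 3 by hydrogen in place of hydroxy on an aromatic carbon. Among the compounds with values here, no measured step removes a single hydroxy; the nearest guides are a 3.1-fold higher number from compound 2 to compound 3 (0.50 log units; beyond the scatter), where both hydroxy groups entered together, and a 1.6-fold lower number from compound 1 to compound 2 (0.21 log units; within the scatter), which fell within the scatter. Taking one hydroxy away is expected to carry compound 4 only part of the way back, a step of a 1.5-fold lower number from compound 3 to compound 4 (0.17 log units; within the scatter). Compound 4 is accordingly estimated at 2200 nM, within a range of 1100 nM to 4500 nM.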

Compound 4, half-maximal inhibitory concentration: 820 nM
For compound 4 the middle estimate is 2.7-fold (0.43 log units) above the measured one; the measured number lies below the stated range.
By their numbers in this assay, from the lowest: compounds 4, 2, 1 and 3 (each within the scatter of the next, the first and the last beyond it).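

In this assay, within the data shown here, the change from 3,4-dihydroxyphenyl to 4-hydroxyphenyl gives a step beyond the scatter on its own (a 4.0-fold lower number from compound 3 to compound 4 (0.60 log units; beyond the scatter)), so the loss of one hydroxy is enough, where the earlier steps could show only both hydroxy groups entering together. The remaining hydroxy matches fluoro at this place (a 1.3-fold lower number from compound 2 to compound 4 (0.10 log units; within the scatter)), while 4-hydroxyphenyl stands apart from 2,4-dimethoxyphenyl (a 2.0-fold lower number from compound 1 to compound 4 (0.31 log units; beyond the scatter)). The compounds shown leave open whether an amine or a carboxylic acid in place of this hydroxy would keep the number of compound 4. No evidence bears on the cause of these steps.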